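The source may hold more compounds than are shown below. What is called first, only, known or untested is meant among the compounds shown, and "the series" means these compounds.

Measured compounds:

- compound 1, `Cc1ccc(C(=O)N[C@@H](C(=O)N2CCC(c3ccc(Cl)cc3)CC2)C(C)C)cc1`: 25 nM
- compound 2, `CC(C)C(NC(=O)c1ccccc1)C(=O)N1CCC(c2ccc(F)cc2)CC1`: 423 nM
- compound 3, `CC[C@@H](C)[C@@H](NC(=O)c1ccccc1)C(=O)N1CCC(c2ccc(Cl)cc2)CC1`: 45 nM

In an assay on THP-1 cells for displacement of a labelled ligand from C-C chemokine receptor type 1 (Homo sapiens) (a higher number here means a weaker inhibitor, a lower number a stronger inhibitor), compound 1 gives the lowest number of the three shown. Compound 3 lies within the usual scatter of compound 1, so the two cannot be ranked against each other. Compound 2 sits well beyond the scatter, and it carries a fluoro rather than a chloro substituent, an unassigned stereocentre and a plain benzoyl group, so its distance from compound 1 cannot be attributed to a single change. Going by the values given here, no step between measured compounds isolates one variable.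

Compound 4, `CC(C)CC(=O)N[C@@H](C(=O)N1CCC(c2ccc(Cl)cc2)CC1)C(C)C`, has not yet been measured in this assay. It differs from compound 1 as follows: isobutyl in place of 4-methylphenyl on a carbonyl carbon. The change replaces the aromatic ring of the amide cap with a short branched chain. The measured compounds carry an aromatic cap throughout, so the series gives no direct reading on this exchange. The aryl amide is common to every active compound here, and removing it is taken as a move away from the pattern that gives the low numbers.

Expectation: compound 4 is estimated to move from compound 1 by a 6.0-fold higher number from compound 1 to compound 4 (0.78 log units; beyond the scatter), a step beyond the scatter toward weaker binding. For compound 4 the value expected in this assay is 150 nM, with a range from 40 nM to 600 nM.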

Compound 4, half-maximal inhibitory concentration: 32 nM
The estimate for compound 4 lay 4.7-fold (0.67 log units) above the measured number; the whole stated range lies above it.
By their numbers in this assay, from the lowest: compounds 1, 4 and 3 (each within the scatter of the next); then compound 2.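

In this assay the exchange of 4-methylphenyl for isobutyl on a carbonyl carbon, whose other neighbour is the amide-type nitrogen, gives a 1.3-fold higher number from compound 1 to compound 4 (0.11 log units; within the scatter), so this pair cannot be ranked. Every earlier compound carried an aromatic cap, and this pair now shows that, on the core of compound 1, an aromatic ring at this position is not needed for a number in this range: a cap with no ring and 4 heavy atoms reads the same, within the scatter, as one with a six-membered aromatic ring and 7 heavy atoms. Nothing available accounts for this tolerance.

The compounds shown do not say how far the position accepts other kinds of group, such as a longer chain like n-hexyl, a cap carrying an amine or a carboxylic acid, or a saturated ring like cyclohexyl. They also leave open whether isobutyl reads the same on a core with fluoro in place of chloro, or with a side chain other than that of compound 1.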